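Swapping the Pyridine for a Furan on the Biaryl Core

The compounds below may be only part of what the source reports. "The series", "measured", "known", "first", "only" and "open" are said of these compounds alone.

Compounds measured so far:
- compound 1 `CCN(c1ccc(C#N)c(Cl)c1)c1cc(-c2ccncc2)ccc1C`: 2900 nM
- compound 2 `N#Cc1ccc(N2CCCc3c(-c4cccnc4)cccc32)cc1C(F)(F)F`: 13500 nM
- compound 3 `N#Cc1ccc(N2CCCc3c(-c4ccncc4)cccc32)cc1C(F)(F)F`: a limit of the assay, > 30000 nM

Among the compounds with values here, in a functional assay on VCaP cells (Homo sapiens) for antiproliferative activity, read by CCK-8 assay, with a stated time of 6 days (on this read-out higher numbers stand for weaker inhibition and lower numbers for stronger inhibition), compound 1 gives 2900 nM, the lower of the two actual numbers measured so far. Compound 2 gives 13500 nM in this assay, a higher number; the two compounds differ in more than one place, so no single cause for the gap can be read off. For compound 3 this assay reports only a limit, > 30000 nM.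

Within the data shown here, the one clean step among the measured compounds is an at least 2.2-fold higher number from compound 2 to compound 3 (0.34 log units; beyond the scatter), which shows that moving the ring nitrogen within an otherwise identical pyridine weakens inhibition by a noticeable margin, with the weaker compound reaching (the limit of > 30000 nM in this assay, at which 1 of the 3 values shown sits).

Compound 4 `CCN(c1ccc(C#N)c(Cl)c1)c1cc(-c2ccoc2)ccc1C` is not yet measured. It differs from compound 1 in one place: furan-3-yl in place of pyridin-4-yl on an aromatic carbon. Among the measured compounds shown here, this is a larger change than the one measured step, since the six-membered ring with its nitrogen gives way to a smaller five-membered ring with an oxygen. Given that the only comparison shows the position of the nitrogen acceptor matters, removing that nitrogen altogether is expected to cost some potency, though the size is uncertain. The estimate for compound 4 is therefore a step of a 1.9-fold higher number from compound 1 to compound 4 (0.28 log units; within the scatter), giving an expected value of 5500 nM with a range from 1500 nM to 20000 nM.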

Compound 4, half-maximal inhibitory concentration: 4010 nM
Compound 4: the middle estimate sits 1.4-fold (0.14 log units) above what was measured, within the range that was stated.
By their numbers in this assay, from the lowest: compounds 1 and 4 (each within the scatter of the next); then compound 2. At a limit, above all of these: compound 3.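

In this assay, the swap gives a 1.4-fold higher number from compound 1 to compound 4 (0.14 log units; within the scatter), so on this aromatic carbon of the core of compound 1, a six-membered pyridin-4-yl ring can give way to a five-membered furan-3-yl ring without a readable change in the number. The ring nitrogen is therefore not needed here to keep inhibition at this level, and an oxygen in a smaller ring serves as well on this read-out. Within the data shown here, the earlier compounds could not show this, since their one clean step only moved a nitrogen around within a pyridine ring on a different core, and never replaced the ring itself. Nothing measured among these compounds explains why the two rings read alike.

On these data alone, both groups compared here are aromatic rings with one hetero atom, so it remains open how this position would respond to a plain phenyl ring with no hetero atom, to a saturated ring such as morpholine, or to a carboxylic acid. As far as these compounds go, it is also open whether furan-3-yl would behave in the same way on the core shared by compound 2 and compound 3.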